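Pentafluorosulfanyl in Place of Trifluoromethyl: Expected Clearance

This account rests on a few compounds, and the source may have more. Where it says the series, first, only, none or still open, it means among the compounds named here.

Measured compounds:
Compound 1 `Cc1cc(Nc2ccc(S(F)(F)(F)(F)F)cc2)n2nc(C(F)(F)F)nc2n1` gives < 5 mL.min-1.g-1 in an in vitro ADME assay on microsomes from liver (Homo sapiens) for metabolic stability; on this read-out higher numbers stand for fast clearance and lower numbers for slow clearance; this is a limit of the assay.
Compound 2 `Cc1cc(Nc2ccc(S(F)(F)(F)(F)F)cc2)n2nc(C(C)(F)F)nc2n1` gives < 5 mL.min-1.g-1 in this assay; this too is a limit.
Compound 3 `CSc1nc2nc(C)cc(Nc3ccc(C(F)(F)F)cc3)n2n1` gives 18.7 mL.min-1.g-1 in this assay.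

Within the data shown here, compound 3 stands as the only true number among the three results; the other two sit at the limit of < 5 mL.min-1.g-1 in this assay, at which 2 of the 3 values shown sit, and are limits rather than numbers. Among the measured compounds shown here, the single measured step, a step that the two limits leave unreadable from compound 1 to compound 2, is not readable, since both ends are limits.

Compound 4 `CSc1nc2nc(C)cc(Nc3ccc(S(F)(F)(F)(F)F)cc3)n2n1` differs from compound 3 by a group of 6 heavy atoms (5 fluorine, 1 sulfur; no ring) in place of a group of 4 heavy atoms (1 carbon, 3 fluorine; no ring), on an aromatic carbon. No measured step of this kind is available, so its size cannot be taken from the shown data. Compound 4 shares with compound 1 and compound 2 the group that enters, and those two compounds sit at the limit of < 5 mL.min-1.g-1 in this assay, at which 2 of the 3 values shown sit. Compound 4 shares with compound 3 the rest of its structure. The expected step is therefore a 1.7-fold lower number from compound 3 to compound 4 (0.23 log units; within the scatter), downward, though the size is uncertain.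

Compound 4 is estimated at 11 mL.min-1.g-1 in this assay, with a range from 4 mL.min-1.g-1 to 30 mL.min-1.g-1.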

Compound 4, intrinsic clearance in microsomes: 22.4 mL.min-1.g-1
Estimate against measurement, compound 4: 2.0-fold (0.31 log units) below; the measured number falls inside the stated range.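

In this assay, the group of 6 heavy atoms (5 fluorine, 1 sulfur) in place of trifluoromethyl gives a 1.2-fold higher number from compound 3 to compound 4 (0.08 log units; within the scatter), so with methylsulfanyl held constant the two groups cannot be told apart on this read-out. With that same group held constant, methylsulfanyl in place of 1,1-difluoroethyl gives an at least 4.4-fold higher number from compound 2 to compound 4 (0.65 log units; beyond the scatter), and methylsulfanyl in place of trifluoromethyl gives an at least 4.4-fold higher number from compound 1 to compound 4 (0.65 log units; beyond the scatter), so among these compounds the clear difference goes with methylsulfanyl and not with the change on the six-membered ring. The step between compound 1 and compound 2 cannot be read, as each of the two is a limit of the assay and not a number: the limit of < 5 mL.min-1.g-1 in this assay, at which 2 of the 4 values shown sit.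

The compounds shown leave open whether the two groups on the six-membered ring would also match with trifluoromethyl or 1,1-difluoroethyl in the place of methylsulfanyl. They also leave open how an amine or a longer chain in that place would read in this assay.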